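Aryl Variation on a Cytotoxicity Read-out

This account rests on a few compounds, and the source may have more. Where it says the series, first, only, none or still open, it means among the compounds named here.

Three analogues sharing one core have been measured in an ADME assay on HEK293 cells (Homo sapiens) for cytotoxicity, read by MTT assay, with a stated time of 48 h; on this read-out lower numbers stand for stronger inhibition and higher numbers for weaker inhibition. Compound 1 `COc1ccc(N/C(CCNC2=CC(=O)c3ccccc3C2=O)=N\S(=O)(=O)c2ccc(C)cc2)cc1` gives 35100 nM; compound 2 `Cc1ccc(S(=O)(=O)/N=C(/CCNC2=CC(=O)c3ccccc3C2=O)Nc2ccc(F)cc2)cc1` gives 55100 nM; compound 3 `Cc1ccc(S(=O)(=O)/N=C(/CCNC2=CC(=O)c3ccccc3C2=O)Nc2ccccc2[N+](=O)[O-])cc1` gives 69600 nM. The steps between them, a 1.6-fold higher number from compound 1 to compound 2 (0.20 log units; within the scatter), a 2.0-fold higher number from compound 1 to compound 3 (0.30 log units; within the scatter) and a 1.3-fold higher number from compound 2 to compound 3 (0.10 log units; within the scatter), all lie within the scatter, so compound 3 cannot be set apart from the others. Compound 4 `Cc1ccc(S(=O)(=O)/N=C(/CCNC2=CC(=O)c3ccccc3C2=O)Nc2cccc(C)c2)cc1` differs from compound 3 by 3-methylphenyl in place of 2-nitrophenyl on an amine nitrogen. The measured aryl changes, a 2.0-fold higher number from compound 1 to compound 3 (0.30 log units; within the scatter) and a 1.3-fold higher number from compound 2 to compound 3 (0.10 log units; within the scatter), bear on this step, and both were small, so no step beyond the scatter is expected in this assay. Compound 4 is therefore estimated at 48000 nM, between 24000 nM and 96000 nM, a step of a 1.5-fold lower number from compound 3 to compound 4 (0.16 log units; within the scatter).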

Compound 4, half-maximal inhibitory concentration: 56200 nM
Beside the measured number, compound 4's estimate is 1.2-fold (0.07 log units) below it; low and high end bracket the measured number.
By their numbers in this assay, from the lowest: compounds 1, 2, 4 and 3 (each within the scatter of the next).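

In this assay, the steps of a 1.2-fold lower number from compound 3 to compound 4 (0.09 log units; within the scatter), a 1.0-fold higher number from compound 2 to compound 4 (0.01 log units; within the scatter) and a 1.6-fold higher number from compound 1 to compound 4 (0.20 log units; within the scatter) all lie within the scatter. The earlier aryl groups on this amine nitrogen each carried nitrogen, oxygen or fluorine on the ring, whereas 3-methylphenyl is made of carbon only, and the number still cannot be set apart from theirs. Nothing available explains this closeness. On these data alone, it remains open whether a carboxylic acid or an amine on the aryl ring, or a cyclohexyl group in its place, would produce a step beyond the scatter.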